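Replacing the trifluoromethoxy group's ring in compound 3

The source may report more compounds than this note shows. Statements on the series, on what has been measured and on what is new or still open speak of the compounds shown alone.

compound 1 `FC(F)(F)Oc1ccc(-c2ccc(-c3ccc(-c4nc5ccccc5[nH]4)cc3)cc2)cc1` gives 38400 nM
compound 2 `COc1ccc(-c2ccc(-c3ccc(-c4nc5ccccc5[nH]4)cc3)cc2)cc1` gives 33300 nM
compound 3 `Oc1cccc2[nH]c(-c3ccc(-c4ccc(-c5ccc(OC(F)(F)F)cc5)cc4)cc3)nc12` gives 2210 nM

In a functional assay on MCF7 cells (Homo sapiens) for inhibition, read by sulforhodamine B assay (on this read-out higher numbers stand for weaker inhibition of growth and lower numbers for stronger inhibition of growth), compound 3 has the lowest number of the three at 2210 nM and compound 1 and compound 2 both lie well above it. The large measured step is a 17-fold lower number from compound 1 to compound 3 (1.24 log units; beyond the scatter) and it came with hydroxy in place of hydrogen on an aromatic carbon. Among the measured compounds shown here, compound 4 `Oc1cccc2[nH]c(-c3ccc(-c4ccc(-c5cccc(Cl)c5)cc4)cc3)nc12` keeps that hydroxy and carries 3-chlorophenyl in place of 4-(trifluoromethoxy)phenyl on an aromatic carbon as its only change. For the measured compounds named here, no measured step exchanges this whole group, so the evidence is thin. Going by the values given here, the one measured change inside the group is a 1.2-fold lower number from compound 1 to compound 2 (0.06 log units; within the scatter) and it suggests that the number in this assay may follow the hydroxy more than this group. No step beyond the scatter is therefore expected, though the range is kept wide. The estimated value for compound 4 is 2500 nM with an expected range from 900 nM to 7000 nM in this read-out. This estimate means a 1.1-fold higher number from compound 3 to compound 4 (0.05 log units; within the scatter) as the expected step.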

Compound 4, concentration for 50% growth inhibition: 3420 nM
For compound 4 the middle estimate is 1.4-fold (0.14 log units) below the measured one; measured number inside the range.
By their numbers in this assay, from the lowest: compounds 3 and 4 (each within the scatter of the next); then compounds 2 and 1 (each within the scatter of the next).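

In this assay, exchanging the whole group at this place, on an aromatic carbon para to a large group, gives a 1.5-fold higher number from compound 3 to compound 4 (0.19 log units; within the scatter), so 3-chlorophenyl and 4-(trifluoromethoxy)phenyl are not told apart here with the hydroxy kept. The earlier step within the group changed only what sits on the oxygen, in compounds without the hydroxy, whereas this one swaps the ring substituent and its place on the ring, and the number still stays within the scatter. No measurement at hand accounts for this result.

As far as these compounds go, whether an amine or a carboxylic acid on this terminal ring would hold the number in the same range remains open. Also open, from the compounds shown here alone, is whether the large hydroxy step seen with 4-(trifluoromethoxy)phenyl carries over to 3-chlorophenyl.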